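Swapping a methylphenyl for a nitrophenyl at the benzyl ether

This account rests on a few compounds, and the source may have more. Where it says the series, first, only, none or still open, it means among the compounds named here.

Compound 1 `COc1cccc(OC)c1OCCNCCOc1ccccc1OCc1ccccc1C` and compound 2 `COc1cccc(OC)c1OCCNCCOc1ccccc1OCc1cccc(C)c1` share one core and differ only in the methylphenyl attached through a saturated chain carbon to an oxygen on an aromatic ring. In a functional assay on PC-3 cells (Homo sapiens) for cytotoxicity, read by sulforhodamine B assay (on this read-out lower numbers stand for stronger inhibition of growth and higher numbers for weaker inhibition of growth), compound 1 gives 11500 nM, and compound 2 gives 12000 nM; the step of a 1.0-fold higher number from compound 1 to compound 2 (0.02 log units; within the scatter) is within the scatter, so the two measured numbers stand side by side and neither can be set above the other. Compound 3 `COc1cccc(OC)c1OCCNCCOc1ccccc1OCc1ccc([N+](=O)[O-])cc1` is not yet measured; it differs from compound 1 by 4-nitrophenyl in place of 2-methylphenyl on a saturated chain carbon bound to an oxygen on an aromatic ring. Among the measured compounds shown here, the only measured step concerns moving a methyl group, not replacing it with a nitro group, so no measured step bears directly on this change, and the expectation is for no step beyond the scatter, with wide uncertainty. Compound 3 is therefore estimated at 11000 nM, with a range from 4000 nM to 30000 nM, which means an expected step of a 1.0-fold lower number from compound 1 to compound 3 (0.02 log units; within the scatter).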

Compound 3, concentration for 50% growth inhibition: 12000 nM
Estimate against measurement, compound 3: 1.1-fold (0.04 log units) below; the range from low to high includes it.
By their numbers in this assay, from the lowest: compounds 1, 2 and 3 (each within the scatter of the next).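

In this assay, replacing a methylphenyl with 4-nitrophenyl gives a 1.0-fold higher number from compound 1 to compound 3 (0.02 log units; within the scatter) and no change at the digits printed from compound 2 to compound 3 (within the scatter). Until now, this position had shown only a methyl group moved around the ring; these steps show that a different group, with hydrogen-bond acceptors that 2-methylphenyl lacks, also leaves the number within the scatter, so all three compounds stand side by side. No measurement here accounts for this lack of separation.

From the compounds shown here alone, whether any group at this position can produce a step beyond the scatter remains open, for example an amine or a carboxylic acid on the ring, or a longer chain between the ring and the ether oxygen. Going by these compounds, all three compounds also share the same core, so the contribution of the rest of the molecule remains open too.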